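Cytotoxicity notes on compounds 1 to 4

A few compounds are considered here, and "the series" means these few. Any claim that something is new, unique, unknown or untested is made for them only; others in the source may bear on it.

Measured compounds:
compound 1 `Nc1cccn2cc(Cc3ccccc3)c(=O)nc12`: 112000 nM
compound 2 `O=c1nc2ccccn2cc1Cc1ccccc1`: a limit, > 1000000 nM
compound 3 `Nc1cc(Br)cn2cc(Cc3ccccc3)c(=O)nc12`: a limit, > 1000000 nM

In a functional assay on HeLa cells (Homo sapiens) for cytotoxicity, read by MTT assay, with a stated time of 24 h (a higher number here means a weaker inhibitor, a lower number a stronger inhibitor), compound 1 gives 112000 nM. Compound 2 gives only a limit, > 1000000 nM. Compound 3 likewise gives only a limit, > 1000000 nM. The two cores differ as hydrogen in place of amino on an aromatic carbon, and this change gives an at least 8.9-fold higher number from compound 1 to compound 2 (0.95 log units; beyond the scatter). The change bromo in place of hydrogen on an aromatic carbon gives an at least 8.9-fold higher number from compound 1 to compound 3 (0.95 log units; beyond the scatter). Both steps have only a lower bound due to the limit of > 1000000 nM in this assay, at which 2 of the 3 values shown sit.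

Compound 4 `O=c1nc2ccccn2cc1Cc1ccc(Br)cc1` is not yet measured. It differs from compound 2 by bromo in place of hydrogen on an aromatic carbon, the same kind of change as from compound 1 to compound 3, but the place differs: in compound 3 the bromo sits on a six-membered aromatic ring with 1 nitrogen, part of a fused or bridged system of two rings, meta to an amino group, whereas in compound 4 it sits on a six-membered aromatic ring of carbon only, para to a large group. Compound 2 already stands at the limit, > 1000000 nM. Given that the earlier bromo step an at least 8.9-fold higher number from compound 1 to compound 3 (0.95 log units; beyond the scatter) raised the number, no gain is expected. In this assay compound 4 is expected to show a number no higher from compound 2 to compound 4 (the limit leaves the size open). Compound 4 is estimated at 1000000 nM, expected between 300000 nM and 3000000 nM, most likely reported only as a limit.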

Compound 4, half-maximal inhibitory concentration: > 1000000 nM
Compound 4: no number, only a limit; the forecaster's own chance of this, stated with the estimate: 85%; the middle value lies on the limit itself.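

Compound 2 and compound 4 both stand only at a limit in this assay, so the step between them cannot be read: the limit of > 1000000 nM in this assay, at which 3 of the 4 values shown sit.

The compounds shown leave open whether bromo in place of hydrogen on a six-membered aromatic ring of carbon only, para to a large group, changes the number at all, and in which direction.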